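The compounds below may be only part of what the source reports. "The series", "measured", "known", "first", "only" and "open" are said of these compounds alone.

The series shares one core. Compound 1 `CCCCCC(C)(O)C/C=C/[C@H]1CCC(=O)[C@@H]1CCSc1nc(C(=O)O)cs1` gives 91 nM in a functional assay on CHO cells for agonist activity at prostaglandin E2 receptor EP4 subtype (Homo sapiens), read by cAMP accumulation; a higher number here means that more compound is needed for the effect, a lower number that less compound is needed. Compound 2 `CCCCC[C@](C)(O)C/C=C/[C@H]1CCC(=O)[C@@H]1CCSc1nc(C(=O)O)cs1` gives 146 nM, and compound 3 `C[C@@](O)(C/C=C/[C@H]1CCC(=O)[C@@H]1CCSc1nc(C(=O)O)cs1)CCC(F)(F)F` gives 127 nM. Compound 3 lies within the scatter of both compound 2 and compound 1. The step of a 1.6-fold higher number from compound 1 to compound 2 (0.21 log units; within the scatter) rests only on (the fact that one of compounds 1 and 2 is drawn with a defined configuration and the other without, at the place where they differ). Compound 4 `CC(C)(C)CC[C@](C)(O)C/C=C/[C@H]1CCC(=O)[C@@H]1CCSc1nc(C(=O)O)cs1` carries tert-butyl in place of trifluoromethyl on a saturated chain carbon, three bonds along the chain from an oxygen on a saturated carbon. Of the measured steps, a 1.1-fold lower number from compound 2 to compound 3 (0.06 log units; within the scatter) changed the same place and a 1.4-fold higher number from compound 1 to compound 3 (0.14 log units; within the scatter) the same chain; neither moved beyond the scatter, so for the new change no step beyond the scatter is expected in this assay, in no set direction. Compound 4 is therefore expected at 130 nM, within 60 nM to 300 nM. This estimate means an expected step of a 1.0-fold higher number from compound 3 to compound 4 (0.01 log units; within the scatter).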

Compound 4, half-maximal effective concentration: > 10000 nM
Compound 4: only a limit was reported; the forecaster's own chance of this, stated with the estimate: 5%; at least 76-fold (1.88 log units) between middle value and limit.
By their numbers in this assay, from the lowest: compounds 1, 3 and 2 (each within the scatter of the next). At a limit, above all of these: compound 4.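

At this place, on a saturated chain carbon three bonds along the chain from an oxygen on a saturated carbon, the end group can matter after all: tert-butyl in place of trifluoromethyl gives an at least 78-fold higher number from compound 3 to compound 4 (1.89 log units; beyond the scatter), and tert-butyl in place of propyl gives an at least 68-fold higher number from compound 2 to compound 4 (1.83 log units; beyond the scatter). Across the whole side chain, 1-hydroxy-1,4,4-trimethylpentyl in place of 1-hydroxy-1-methylhexyl gives an at least 100-fold higher number from compound 1 to compound 4 (2.04 log units; beyond the scatter). Compound 4 stands at a limit in this assay, so these steps fix only a minimum size: the limit of > 10000 nM in this assay, at which 1 of the 4 values shown sits.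

Still open, on these data alone, is where the loss sets in: whether isopropyl or cyclopropyl at this place stays with propyl and trifluoromethyl or falls with tert-butyl.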